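The compounds below may be only part of what the source reports. "The series", "measured", "known", "first", "only" and "open" are said of these compounds alone.

Measured compounds: compound 1 `CCCCCCCCCCCCCC[C@@H](O)[C@@H](O)[C@H](CO)n1cc(CCCCCC)nn1` gives 13700 nM in a functional assay on NCI-H358 cells (Homo sapiens) for cytotoxicity, read by sulforhodamine B assay; a higher number here means that more compound is needed for the effect, a lower number that less compound is needed; compound 2 `CCCCCCCCCCCCC/C=C/[C@@H](O)[C@H](CO)NC(C)=O` gives 19600 nM; compound 3 `CCCCCCCCCCCCC/C=C/[C@@H](O)[C@H](CO)n1cc(CCC)nn1` gives 15700 nM.

Compound 1 stands within the scatter of both compound 3 and compound 2, so the three numbers cannot be ranked. Among the compounds with values here, the only single-site step, a 1.2-fold lower number from compound 2 to compound 3 (0.10 log units; within the scatter), exchanges the acetamido group for a triazole and does not touch the alkyl chain on the triazole. Compound 4 `CCCCCCCCCCCCCC[C@@H](O)[C@@H](O)[C@H](CO)n1cc(CCCCCCCCCCCCC)nn1` differs from compound 1 by heptyl in place of hydrogen on a saturated chain carbon, six bonds along the chain from an aromatic carbon. Within the data shown here, no measured step lengthens that chain, and compounds 1 and 3 differ in two places, so their values alone cannot be read as a chain effect. With nothing to point to a direction, the step of a 1.1-fold lower number from compound 1 to compound 4 (0.02 log units; within the scatter) is expected to stay within the scatter, and compound 4 is estimated at 13000 nM with a range of 5000 nM to 35000 nM.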

Compound 4, half-maximal effective concentration: > 50000 nM
Compound 4: only a limit was reported (the forecaster's own chance of this, stated with the estimate: 10%); middle value at least 3.8-fold (0.58 log units) from the limit.
By their numbers in this assay, from the lowest: compounds 1, 3 and 2 (each within the scatter of the next). At a limit, above all of these: compound 4.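

In this assay, the group on the triazole proves not to be neutral at this position: heptyl in place of hydrogen, six bonds along the chain from an aromatic carbon, gives an at least 3.6-fold higher number from compound 1 to compound 4 (0.56 log units; beyond the scatter), the only step shown that lies beyond the scatter. The number for compound 4 is a limit of the assay, not a measured value, so the true size of the step stays unknown: the limit of > 50000 nM in this assay, at which 1 of the 4 values shown sits.

The compounds shown leave open whether a shorter extension, such as an octyl or decyl chain at this place, already raises the number. They also leave open whether an amine carried on the chain would do the same.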